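Moving a Hydroxyl Group Past an Assay Limit

The compounds below may be only part of what the source reports. "The series", "measured", "known", "first", "only" and "open" are said of these compounds alone.

Compound 1 `Oc1ccc(-c2cc(-c3cccs3)cc(-c3ccccc3O)n2)cc1`, in a functional assay on HCT-15 cells (Homo sapiens) for cytotoxicity, read by CCK-8 assay (on this read-out higher numbers stand for weaker inhibition and lower numbers for stronger inhibition), sits at the limit > 50000 nM.
Compound 2 `Oc1ccc(-c2cc(-c3ccco3)cc(-c3ccccc3O)n2)cc1` sits at the limit > 50000 nM.
Compound 3 `Oc1cccc(-c2cc(-c3ccoc3)cc(-c3ccccc3O)n2)c1` sits at the limit > 50000 nM.

Compound 3 therefore stands where every measured compound stands, at the ceiling of this assay with no number of its own, as the limit of > 50000 nM in this assay, at which 3 of the 3 values shown sit, records. The step from compound 1 to compound 2, a step that the two limits leave unreadable from compound 1 to compound 2, is left unreadable by the two limits. Compound 4 `Oc1ccc(-c2cc(-c3ccoc3)cc(-c3ccccc3O)n2)cc1` differs from compound 3 by 4-hydroxyphenyl in place of 3-hydroxyphenyl on an aromatic carbon. For the measured compounds named here, no measured step bears directly on this change, but compounds 1 and 2, which carry the 4-hydroxyphenyl group that enters, both sit at the limit. Compound 4 is therefore expected to remain at the limit, an estimated step that the limit leaves unreadable from compound 3 to compound 4, with an estimate of 80000 nM in the range 30000 nM to 300000 nM.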

Compound 4, half-maximal inhibitory concentration: > 50000 nM
Compound 4: a limit, no number (the forecaster's own chance of this, stated with the estimate: 85%); the middle value does not contradict the limit.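

Compound 4 also sits at a limit, so its steps from compound 1, compound 2 and compound 3 cannot be read. The compounds shown leave open whether any of these changes shifts the read-out at all, for all four share one ceiling: the limit of > 50000 nM in this assay, at which 4 of the 4 values shown sit.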